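Aryl ketone in place of aryl ether on the piperidine

A few compounds are considered here, and "the series" means these few. Any claim that something is new, unique, unknown or untested is made for them only; others in the source may bear on it.

Within the data shown here, compound 2 `O=C1c2ccccc2CCCN1CCN1CCC(Oc2ccc(F)cc2)CC1` gives the lower of the two numbers so far in an assay on isolated protein for binding affinity to 5-hydroxytryptamine receptor 7 (Homo sapiens) (a higher number here means a weaker inhibitor, a lower number a stronger inhibitor), with 4.47 nM; compound 1 `O=C1CC(CN2CCC(Oc3ccccc3)CC2)CCc2ccccc21` gives 18.6 nM, a gap beyond the scatter. Compound 3 `O=C(c1ccc(F)cc1)C1CCN(CCN2CCCc3ccccc3C2=O)CC1` carries (4-fluorophenyl)carbonyl in place of 4-fluorophenoxy on a saturated ring carbon. Among the measured compounds shown here, no measured pair shows this change on its own, so the size of the step is open; the expected step of a 1.8-fold higher number from compound 2 to compound 3 (0.25 log units; within the scatter) is a modest loss, close to the edge of the scatter. In this assay compound 3 is estimated at 8 nM, with a range from 2.5 nM to 30 nM.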

Compound 3, inhibition constant: 1.66 nM
Beside the measured number, compound 3's estimate is 4.8-fold (0.68 log units) above it, outside the stated range (below it).
By their numbers in this assay, from the lowest: compound 3; then compound 2; then compound 1.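

On a saturated ring carbon, three ring bonds from the ring nitrogen, (4-fluorophenyl)carbonyl can replace 4-fluorophenoxy: in this assay the change gives a 2.7-fold lower number from compound 2 to compound 3 (0.43 log units; beyond the scatter), a modest gain beyond the scatter. This first single-place step in the series shows that 4-fluorophenoxy is not required at this position. Nothing on hand accounts for the step.

The compounds shown leave open how a sulfonyl or a secondary amine would compare with the carbonyl here, and what the fluorine contributes to the phenyl ring.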